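The compounds below may be only part of what the source reports. "The series", "measured", "known", "first", "only" and "open" are said of these compounds alone.

Going by the values given here, in a functional assay on HEK293 cells for agonist activity at D(4) dopamine receptor (Homo sapiens), read by FLIPR (a lower number here means that less compound is needed, a higher number that more compound is needed for the effect), compound 2 `O=C(NCN1CCC(c2cccc[n+]2[O-])CC1)c1ccccn1` gives 3150 nM, the highest of the two numbers known; compound 1 `N#Cc1cccc(C(=O)NCN2CCC(c3cccc[n+]3[O-])CC2)c1` gives 840 nM. Among the compounds with values here, the one measured step, a 3.8-fold higher number from compound 1 to compound 2 (0.57 log units; beyond the scatter), bears on compound 3 `Cc1cc(C(=O)NCN2CCC(c3cccc[n+]3[O-])CC2)ccc1Cl`, which carries the change (4-chloro-3-methylphenyl in place of pyridin-2-yl on a carbonyl carbon). This returns a six-membered aromatic ring of carbon only to the carbonyl carbon, so the expected step in this assay is estimated as a 4.5-fold lower number from compound 2 to compound 3 (0.65 log units; beyond the scatter), about the size of the earlier step but reversed. Compound 3 is therefore estimated at 700 nM, within a range of 250 nM to 2000 nM.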

Compound 3, half-maximal effective concentration: 2460 nM
Compound 3: middle estimate off by 3.5-fold (0.55 log units), on the low side; the whole stated range lies below it.
By their numbers in this assay, from the lowest: compound 1; then compounds 3 and 2 (each within the scatter of the next).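

In this assay, 4-chloro-3-methylphenyl in place of pyridin-2-yl on the carbonyl carbon gives a 1.3-fold lower number from compound 2 to compound 3 (0.11 log units; within the scatter), so a six-membered aromatic ring of carbon only does not by itself bring the number back to that of compound 1. Set against 3-cyanophenyl, the same group gives a 2.9-fold higher number from compound 1 to compound 3 (0.47 log units; beyond the scatter), which leaves compound 1 alone apart from the other two. No evidence on the reason for this result is available. Still open, going by these compounds, is whether the nitrile of compound 1 is what sets it apart, and what an unsubstituted phenyl, a carboxylic acid or an amine would give in this place.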